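Benzyloxycarbonyl to carboxy on the shared core

A few compounds are considered here, and "the series" means these few. Any claim that something is new, unique, unknown or untested is made for them only; others in the source may bear on it.

In a functional assay on NALM-6 cells (Homo sapiens) for cytotoxicity, with a stated time of 72 h (a higher number here means that more compound is needed for the effect, a lower number that less compound is needed), compound 1 (`C=C[C@@](C)(/C=C/c1ccc(O)c(CO)c1)CCC=C(C)C`) gives 16400 nM. Compound 2 (`C=C[C@@](C)(/C=C/c1ccc(O)c(/C=C/C(=O)OCc2ccccc2)c1)CCC=C(C)C`) reads > 43400 nM, which is a limit of the assay and not a number. Compound 3 (`C=C[C@@](C)(/C=C/c1ccc(O)c(/C=C/C(=O)O)c1)CCC=C(C)C`) differs from compound 2 by hydrogen in place of benzyl on an oxygen next to a carbonyl group. Among the measured compounds shown here, no measured step covers this change, and compound 1 at 16400 nM is the only number. In this assay a small move toward lower numbers is expected, or none beyond the scatter, and the estimated change is an at least 1.2-fold lower number from compound 2 to compound 3 (0.09 log units; that floor lies within the scatter). Compound 3 is expected at 35000 nM, with an estimated range of 12000 nM to 90000 nM.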

Compound 3, half-maximal effective concentration: > 43400 nM
Compound 3: a limit, no number (the forecaster's own chance of this, stated with the estimate: 45%); at least 1.2-fold (0.09 log units) between middle value and limit.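

In this assay compound 3 reads > 43400 nM, a limit of the assay and not a number. The carboxy form, like the benzyloxycarbonyl form, gives no number, so the step between them cannot be read: the limit of > 43400 nM in this assay, at which 2 of the 3 values shown sit.

Among the compounds shown here, the first readable step at this position is 2-carboxyethenyl in place of hydroxymethyl on an aromatic carbon, with an at least 2.6-fold higher number from compound 1 to compound 3 (0.42 log units; beyond the scatter).

Going by these compounds, how far compound 2 and compound 3 lie past the limit stays open. Also open, on these data alone, is whether an amide or an amine in place of the carboxy group would give a number in this assay.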